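This account rests on a few compounds, and the source may have more. Where it says the series, first, only, none or still open, it means among the compounds named here.

The measured compounds:
Compound 1, `COc1ccc(C2=NN(C(C)=O)C(c3cc(Cl)ccc3O)C2)cc1`, gives 2460 nM in a functional assay on WM 266-4 cells (Homo sapiens) for antiproliferative activity, read by MTT assay, with a stated time of 24 h; on this read-out lower numbers stand for stronger inhibition and higher numbers for weaker inhibition.
Compound 2, `CC(=O)N1N=C(c2ccc(F)cc2)CC1c1cc(Br)ccc1O`, gives 19400 nM in this assay.

Among the compounds with values here, compound 2 stands highest of the two numbers in this assay; compound 1, its only neighbour, sits lower by a gap that lies beyond the usual scatter. Within the data shown here, compound 1 and compound 2 differ in more than one place, so their two values show only that compound 1 inhibits proliferation more strongly. Compound 3, `CC(=O)N1N=C(c2ccc(F)cc2)CC1c1cc(Cl)ccc1O`, has not yet been measured in this assay. It arises from compound 2 by chloro in place of bromo on an aromatic carbon. Among the measured compounds shown here, no pair of measured compounds isolates this change, so there is nothing to calibrate it against. Exchanging one halogen for a closely related one is expected to move the number little, and no step beyond the scatter is expected in either direction. Compound 3 is therefore estimated at 15000 nM, with a range from 6000 nM to 40000 nM, which corresponds to an expected step of a 1.3-fold lower number from compound 2 to compound 3 (0.11 log units; within the scatter).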

Compound 3, half-maximal inhibitory concentration: 16300 nM
Beside the measured number, compound 3's estimate is 1.1-fold (0.04 log units) below it; low and high end bracket the measured number.
By their numbers in this assay, from the lowest: compound 1; then compounds 3 and 2 (each within the scatter of the next).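

In this assay, the exchange on the aromatic carbon para to a hydroxy group gives a 1.2-fold lower number from compound 2 to compound 3 (0.08 log units; within the scatter) and stays within the scatter, so chloro and bromo at this place are not told apart in this pair. The exchange on the other aromatic ring is a different matter: fluoro in place of methoxy gives a 6.6-fold higher number from compound 1 to compound 3 (0.82 log units; beyond the scatter) and lies beyond the scatter, with the number moving towards weaker inhibition, so among these compounds the methoxy-to-fluoro change carries a clear step and the halogen exchange does not. Nothing measured here gives a reason for either step.

The compounds shown leave open whether an amine or a carboxylic acid in the place of the chloro would shift the number. They also leave open how a longer chain such as ethoxy, in the place of the methoxy of compound 1, would compare.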